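From 3-Fluorophenyl to 4-Fluorophenyl on the Sulfonamide

The source may hold more compounds than are shown below. What is called first, only, known or untested is meant among the compounds shown, and "the series" means these compounds.

Three compounds have been measured in an assay on HEK293 cells for displacement of a labelled ligand from 5-hydroxytryptamine receptor 7 (Homo sapiens), read by scintillation counting, with a stated time of 1 h; a higher number here means a weaker inhibitor, a lower number a stronger inhibitor:
compound 1 `CC(C)c1ccccc1OCC(C)N1CCC(NS(=O)(=O)c2ccc(F)cc2)CC1` gives 74 nM;
compound 2 `CC(COc1ccccc1-c1ccccc1)N1CCC(NS(=O)(=O)c2cccc(Cl)c2)CC1` gives 32 nM;
compound 3 `CC(C)c1ccccc1OCCCN1CCC(NS(=O)(=O)c2cccc(F)c2)CC1` gives 52 nM.

Compound 3 stands second highest of the three numbers; its nearest neighbour is compound 1 and its furthest is compound 2, and both gaps lie within the scatter. Compound 4 `CC(C)c1ccccc1OCCCN1CCC(NS(=O)(=O)c2ccc(F)cc2)CC1` differs from compound 3 in one place: 4-fluorophenyl in place of 3-fluorophenyl on a sulfonyl sulfur. For the measured compounds named here, no pair of measured compounds isolates this change; compounds 1 and 3 differ in the fluorophenyl and in the chain at once, and their values merely lie within the scatter of one another. For compound 4 the account therefore expects no step beyond the scatter, namely a 1.2-fold higher number from compound 3 to compound 4 (0.06 log units; within the scatter). Compound 4 is estimated at 60 nM in this assay, with a range from 25 nM to 150 nM.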

Compound 4, inhibition constant: 32 nM
Compound 4: middle estimate off by 1.9-fold (0.27 log units), on the high side; the measured number falls inside the stated range.
By their numbers in this assay, from the lowest: compounds 2, 4, 3 and 1 (each within the scatter of the next, the first and the last beyond it).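

For the compounds shown here, compound 3 and compound 4 form the first pair that isolates this change. In this assay, 4-fluorophenyl in place of 3-fluorophenyl on a sulfonyl sulfur gives a 1.6-fold lower number from compound 3 to compound 4 (0.21 log units; within the scatter), so with the chain held constant, these two fluorophenyl groups are not told apart at this position. Nothing available explains this result.

As far as these compounds go, it remains open whether a trifluoromethyl group in place of the fluorine would give a step beyond the scatter. From the compounds shown here alone, it is also open whether the same change would read alike on the chain of compound 1.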